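The source may hold more compounds than are shown below. What is called first, only, known or untested is meant among the compounds shown, and "the series" means these compounds.

Measured so far:
compound 1 `CCN1CCN(CCCn2cnc3c(N4CCN(CC)CC4)nc(N4CCCC4)nc32)CC1` — 500 nM
compound 2 `CN(C)Cc1ccc(CNc2nc(N3CCN(C4CCCC4)CC3)c3ncn(CCCN4CCCC4)c3n2)cc1` — 7 nM
compound 3 `CCN1CCN(c2nc(NCc3ccc(CN(C)C)cc3)nc3c2ncn3CCCN2CCCC2)CC1` — 90 nM

In an assay on HEK293 cells for antagonist activity at Toll-like receptor 9 (Homo sapiens), read by spectrophotometry (on this read-out lower numbers stand for stronger inhibition and higher numbers for weaker inhibition), compound 3 stands second highest of these three numbers: compound 1 gives a higher number, compound 2 a lower one, and both gaps lie beyond the scatter. Among the compounds with values here, the only step between two compounds that differ in a single place is a 13-fold higher number from compound 2 to compound 3 (1.11 log units; beyond the scatter), a large change that comes from swapping ethyl for cyclopentyl on an amine nitrogen in a ring, a place untouched in the next step.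

Compound 4 `CCN1CCN(c2nc(NCc3ccc(OC)cc3)nc3c2ncn3CCCN2CCCC2)CC1` differs from compound 3 elsewhere: methoxy in place of (dimethylamino)methyl on an aromatic carbon. Within the data shown here, no measured pair shows this particular exchange, so nothing seen so far gives its size or direction. The nearest hint is that compound 1, which carries no benzylamino group at all, gives 500 nM in this assay, a weaker result than compound 3, but that is a much larger change than the one made here.

On that thin basis compound 4 is expected to give a somewhat higher number, with the step of a 2.8-fold higher number from compound 3 to compound 4 (0.44 log units; beyond the scatter) taken as the estimate. Compound 4 is therefore estimated at 250 nM, within a range from 70 nM to 900 nM.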

Compound 4, half-maximal inhibitory concentration in the Toll-like receptor 9 assay: 80 nM
Compound 4: middle estimate off by 3.1-fold (0.49 log units), on the high side; low and high end bracket the measured number.
By their numbers in the Toll-like receptor 9 assay, from the lowest: compound 2; then compounds 4 and 3 (each within the scatter of the next); then compound 1.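

In the Toll-like receptor 9 assay this exchange on the aromatic carbon makes no difference that can be read (a 1.1-fold lower number from compound 3 to compound 4 (0.05 log units; within the scatter)), so for this pair the (dimethylamino)methyl group can give way to methoxy with inhibition staying within the scatter. The same exchange does register in a physicochemical assay for solubility, with a stated time of 18 h, at pH 7.4 (on this read-out higher numbers stand for higher solubility and lower numbers for lower solubility), where compound 3 gives 136 ug/mL and compound 4 gives 49.4 ug/mL so that solubility is lower with methoxy: the measured solubility of compound 3, 136 ug/mL, and of compound 4, 49.4 ug/mL, a 2.8-fold lower number (0.44 log units; beyond the scatter). Within the data shown here, earlier, the only single-place step was on the amine nitrogen in a ring, where the Toll-like receptor 9 assay gave a 13-fold higher number from compound 2 to compound 3 (1.11 log units; beyond the scatter), and this new pair adds that a change on the aromatic ring can leave inhibition in place while solubility shifts.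

Two compounds cannot separate the loss of the (dimethylamino)methyl group from the arrival of methoxy, and they cannot say whether the same exchange would behave alike with the cyclopentyl group of compound 2 in place of ethyl. As far as these compounds go, it also remains open how other groups on this aromatic carbon, such as a primary amine, a carboxylic acid or a chlorine atom, would fare in inhibition and solubility.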